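This account rests on a few compounds, and the source may have more. Where it says the series, first, only, none or still open, it means among the compounds named here.

Values measured in an ADME assay on MDCKII-LE cells (Canis lupus familiaris) for permeability; a higher number here means that the compound crosses the layer faster, a lower number that the compound crosses the layer more slowly:
- compound 1 `NC(=O)[C@@H](CCC(F)(F)F)N(CC12CC(c3ncon3)(C1)C2)S(=O)(=O)c1ccc(Cl)cc1`: 19.3 10^-6 cm/s
- compound 2 `N#CC12CC(CN([C@H](CCC(F)(F)F)C(N)=O)S(=O)(=O)c3ccc(Cl)cc3)(C1)C2`: 30.2 10^-6 cm/s
- compound 3 `N#CCCCN([C@H](CCC(F)(F)F)C(N)=O)S(=O)(=O)c1ccc(Cl)cc1`: 27.6 10^-6 cm/s

Compound 3 gives 27.6 10^-6 cm/s, a number that cannot be told apart from the other two, as all three lie within the usual scatter of such measurements. The next compound is compound 4 `N#C[C@H]1C[C@@H](CN([C@H](CCC(F)(F)F)C(N)=O)S(=O)(=O)c2ccc(Cl)cc2)C1`, which has not yet been measured. Its difference from compound 3 is 3-cyanocyclobutyl in place of 2-cyanoethyl on a saturated chain carbon bound to a sulfonamide nitrogen. The nitrile stays, while the group now holds one four-membered non-aromatic ring of carbon only.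

Within the data shown here, three measured steps bear on this change. Compound 2 also carries its cyano group on a saturated ring carbon. Replacing its whole ring group with the open chain gave a 1.1-fold lower number from compound 2 to compound 3 (0.04 log units; within the scatter). The same chain replacing a still larger group gave a 1.4-fold higher number from compound 1 to compound 3 (0.16 log units; within the scatter). Exchanging the 1,2,4-oxadiazol-3-yl for cyano gave a 1.6-fold higher number from compound 1 to compound 2 (0.19 log units; within the scatter). None of these changes moved the number in this assay beyond the scatter, so no shift beyond the scatter is expected here either, in either direction. The expected result is a 1.0-fold higher number from compound 3 to compound 4 (0.01 log units; within the scatter). For compound 4 the estimated value is 28 10^-6 cm/s, with an expected range from 18 10^-6 cm/s to 42 10^-6 cm/s.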

Compound 4, apparent permeability: 24.1 10^-6 cm/s
Beside the measured number, compound 4's estimate is 1.2-fold (0.07 log units) above it, and the stated range covers the measured number.
By their numbers in this assay, from the lowest: compounds 1, 4, 3 and 2 (each within the scatter of the next).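

In this assay, the open chain and the 3-cyanocyclobutyl group cannot be told apart at this position on the saturated chain carbon bound to a sulfonamide nitrogen, with a 1.1-fold lower number from compound 3 to compound 4 (0.06 log units; within the scatter). The earlier compounds shown here had compared the open chain only with groups holding two four-membered rings, and the single ring now fills that gap: a 1.3-fold lower number from compound 2 to compound 4 (0.10 log units; within the scatter) and a 1.2-fold higher number from compound 1 to compound 4 (0.10 log units; within the scatter), so the single-ring compound cannot be told apart from either of them. Across the open chain, the one-ring group and the two-ring groups, the number therefore stays within the scatter, while no information is available here on why these groups read alike.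

The compounds shown leave open whether the other spatial arrangement of the 3-cyanocyclobutyl group would read the same, since only one arrangement of its defined stereocentres appears here. They also leave open whether this tolerance would hold for an amine or a carboxylic acid at the same position, as every group shown ends in a nitrile or a 1,2,4-oxadiazol-3-yl.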